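Thiosemicarbazone series: cytotoxicity notes toward compound 4

The compounds below may be only part of what the source reports. "The series", "measured", "known", "first", "only" and "open" are said of these compounds alone.

Going by the values given here, compound 1 `COc1cc2c(Oc3ccc(NC(=S)N/N=C/c4ccccc4)cc3F)ccnc2cc1OCCCN1CCCCC1` is the only member with a number in an ADME assay on PBL cells (Homo sapiens) for cytotoxicity, read by MTT assay, with a stated time of 72 h; a higher number here means a weaker inhibitor, a lower number a stronger inhibitor: compound 1 gives 78400 nM. Compound 2 `COc1cc2c(Oc3ccc(NC(=S)N/N=C/c4ccc(F)c(F)c4)cc3F)ccnc2cc1OCCCN1CCCCC1` carries no result in this assay, its entry reading "not determined" (no result reported). Among the compounds with values here, compound 3 `COc1cc2c(Oc3ccc(NC(=S)N/N=C/c4ccc(Cl)cc4)cc3F)ccnc2cc1OCCCN1CCCCC1` likewise carries no result in this assay, its entry reading "not determined" (no result reported), so compound 3 stands without a value of its own, and the series offers no measured step between any two compounds. Compound 4 `COc1cc2c(Oc3ccc(NC(=S)N/N=C/c4ccc(F)cc4Cl)cc3F)ccnc2cc1OCCCN1CCCCC1` differs from compound 3 by 2-chloro-4-fluorophenyl in place of 4-chlorophenyl on a carbon with a double bond to nitrogen. Within the data shown here, with no measured pair to lean on, the expected step in this assay is none beyond the scatter in either direction, the only anchor being compound 1 at 78400 nM. Compound 4 is estimated at 75000 nM, with a range from 30000 nM to 150000 nM.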

Compound 4, half-maximal inhibitory concentration: 34100 nM
Compound 4: middle estimate off by 2.2-fold (0.34 log units), on the high side, and the stated range covers the measured number.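

In this assay, going by these compounds alone, the swap of phenyl for 2-chloro-4-fluorophenyl on a carbon with a double bond to nitrogen gives a 2.3-fold lower number from compound 1 to compound 4 (0.36 log units; beyond the scatter) as the only measured step. This position therefore responds to substitution on the phenyl, modestly and toward a stronger inhibitor. No data here bear on why the number moves.

Which of the two halogens carries the step stays open, as does how the number would respond to an amine or a carboxylic acid on that phenyl.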